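A few compounds are considered here, and "the series" means these few. Any claim that something is new, unique, unknown or untested is made for them only; others in the source may bear on it.

Of the compounds shown here, three built on one shared core have been measured in a functional assay on OVCAR-5 cells (Homo sapiens) for inhibition, read by CCK-8 assay, with a stated time of 72 h, tested at 10 uM; a lower number here means less inhibition of growth, a higher number more inhibition of growth at the concentration tested. Compound 1 `CN(C)C(=O)c1cc2cnc(Nc3ccc(NC(=O)C4(C(=O)Nc5ccccc5F)CC4)cc3)nc2n1C1CCCC1` gives 82.6%. Compound 2 `CN(C)C(=O)c1cc2cnc(Nc3ccc(NC(=O)C4(C(=O)Nc5cccc(O)c5)CC4)cc3)nc2n1C1CCCC1` gives 86%. Compound 3 `CN(C)C(=O)c1cc2cnc(Nc3ccc(NC(=O)C4(C(=O)Nc5ccc(Br)cc5)CC4)cc3)nc2n1C1CCCC1` gives 87.8%. On these numbers compound 2 stands second highest of the three, its nearest neighbour being compound 3, a number 1.8 percentage points higher from compound 2 to compound 3 (within the scatter), and its furthest compound 1, a number 3.4 percentage points higher from compound 1 to compound 2 (within the scatter). The remaining comparison, a number 5.2 percentage points higher from compound 1 to compound 3 (within the scatter), is of the same kind. Each of the three steps exchanges one substituted phenyl for another on the same amide-type nitrogen, and none of them moves the read-out beyond the scatter.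

Compound 4 `CN(C)C(=O)c1cc2cnc(Nc3ccc(NC(=O)C4(C(=O)Nc5ccc(O)cc5)CC4)cc3)nc2n1C1CCCC1` differs from compound 2 by 4-hydroxyphenyl in place of 3-hydroxyphenyl on an amide-type nitrogen. All three measured steps bear directly on this change, since each alters the phenyl on that amide-type nitrogen, and each was within the scatter, whether the group was a 2-fluorophenyl, a 3-hydroxyphenyl or a 4-bromophenyl. The expectation is therefore that the step of no change at the digits printed from compound 2 to compound 4 (within the scatter) will also stay within the scatter, with no direction to it. The estimate for compound 4 in this assay is 86%, with a range from 78% to 92%.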

Compound 4, percent growth inhibition at one concentration: 90.9%
The estimate for compound 4 lay 4.9 percentage points below the measured number; low and high end bracket the measured number.
By their numbers in this assay, from the lowest: compounds 1, 2, 3 and 4 (each within the scatter of the next).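

Among the steps shown, this is the only one that keeps the same atoms and joins them differently, placing the hydroxy group of 3-hydroxyphenyl as in 4-hydroxyphenyl on the amide-type nitrogen, and in this assay it reads (a number 4.9 percentage points higher from compound 2 to compound 4 (within the scatter)). The two other new comparisons also stay inside the scatter, one with hydroxy in place of bromo on an aromatic carbon (a number 3.1 percentage points higher from compound 3 to compound 4 (within the scatter)) and one with 4-hydroxyphenyl in place of 2-fluorophenyl (a number 8.3 percentage points higher from compound 1 to compound 4 (within the scatter)), so neither the place of the hydroxy group nor the exchange for a halogen separates compound 4 from the other three compounds at this single concentration. Nothing further is available that would explain these numbers or bear on this result.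

Going by these compounds, what remains open is whether a 2-hydroxyphenyl, an aminophenyl, a phenyl carrying a carboxylic acid, or a plain alkyl chain in place of the phenyl on the amide-type nitrogen would give a step beyond the scatter. With only one concentration shown, it also stays open whether these four compounds would separate in a full concentration series.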